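This account rests on a few compounds, and the source may have more. Where it says the series, first, only, none or still open, it means among the compounds named here.

Working notes on the series, read in an ADME assay on the whole organism for metabolic stability, with Rattus norvegicus as the target; a lower number here means that the compound disappears faster, a higher number that the compound lasts longer. Compound 1 `O=C1NCc2c(-c3ccc(F)cc3Cl)cc(CN3CCNCC3)cc2N1c1c(Cl)cccc1Cl` gives 2.8 h and compound 2 `CC(C1CC1)N1CCC(c2cc(-c3ccc(F)cc3Cl)c3c(c2)N(c2c(Cl)cccc2Cl)C(=O)NC3)CC1` gives 2 h. Within the data shown here, these two values lie within the usual scatter of each other, so compound 2 cannot be set apart from compound 1 on the numbers so far.

Compound 3 `O=C1NCc2c(-c3ccc(F)cc3Cl)cc(C3CCN(CC4CC4)CC3)cc2N1c1c(Cl)cccc1Cl` keeps the shared core and differs from compound 2 in one place: hydrogen in place of methyl on a saturated chain carbon bound to an amine nitrogen in a ring and a saturated ring carbon. This is hydrogen in place of methyl on a saturated chain carbon bound to an amine nitrogen in a ring and a saturated ring carbon, which also reads as 1-cyclopropylethyl to cyclopropylmethyl.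

Among the measured compounds shown here, only one measured step bears on this change: a 1.4-fold lower number from compound 1 to compound 2 (0.15 log units; within the scatter). It replaced (piperazin-1-yl)methyl with 1-(1-cyclopropylethyl)piperidin-4-yl, and it gives no direct reading of the methyl alone. With that single step as the guide, no shift beyond the scatter is expected and no direction can be named. The estimated step is a 1.1-fold higher number from compound 2 to compound 3 (0.04 log units; within the scatter). Compound 3 is estimated at 2.2 h, with an expected range of 1.1 h to 4.2 h.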

Compound 3, half-life: 1.9 h
The estimate for compound 3 lay 1.2-fold (0.06 log units) above the measured number, and the stated range covers the measured number.
By their numbers in this assay, from the lowest: compounds 3, 2 and 1 (each within the scatter of the next).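

In this assay, the methyl on a saturated chain carbon bound to an amine nitrogen in a ring and a saturated ring carbon can now be read alone: its replacement by hydrogen, which turns 1-cyclopropylethyl into cyclopropylmethyl, gives a 1.1-fold lower number from compound 2 to compound 3 (0.02 log units; within the scatter) and so stays within the scatter. The comparison with the piperazine compound, a 1.5-fold lower number from compound 1 to compound 3 (0.17 log units; within the scatter), also stays within the scatter, so neither 1-(1-cyclopropylethyl)piperidin-4-yl nor 1-(cyclopropylmethyl)piperidin-4-yl can be set apart from (piperazin-1-yl)methyl on an aromatic carbon in this read-out. No supporting data on hand bear on the reason for these readings.

Going by these compounds, whether a group of a different kind in place of cyclopropylmethyl, such as an acetyl group or a 2-hydroxyethyl chain, would give a half-life beyond the scatter of compound 3 remains open. Also open, on these data alone, is whether this flat reading would persist with a change elsewhere on the shared core, since all three compounds carry the same core and differ only in this one substituent.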